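The compounds below may be only part of what the source reports. "The series", "measured", "known", "first", "only" and "open" are said of these compounds alone.

Measured compounds:
- Compound 1, `CCCN(CC[C@H]1CC[C@H](NC(=O)/C=C/c2cccc(F)c2)CC1)[C@H]1CCc2nc(N)sc2C1`: in an assay on brain for displacement of a labelled ligand from D(3) dopamine receptor (Rattus norvegicus) (on this read-out lower numbers stand for stronger inhibition and higher numbers for weaker inhibition), compound 1 gives 9.9 nM
- Compound 2, `CCCN(CC[C@H]1CC[C@H](NS(=O)(=O)c2cccc(Cl)c2)CC1)[C@H]1CCc2nc(N)sc2C1`: in this assay compound 2 gives 1.1 nM

Compound 2 has the lowest number of the two measured in this assay; its nearest neighbour is compound 1, and the step of a 9.0-fold lower number from compound 1 to compound 2 (0.95 log units; beyond the scatter) lies beyond the scatter.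

Compound 3, `CCCN(CC[C@H]1CC[C@H](NS(=O)(=O)c2ccccc2Cl)CC1)[C@H]1CCc2nc(N)sc2C1`, has not yet been measured. It differs from compound 2 only in the position of the chlorine on the aromatic ring: 2-chlorophenyl in place of 3-chlorophenyl on a sulfonyl sulfur. The two compounds have the same atoms, joined differently.

Among the compounds with values here, the single measured step, from compound 1 to compound 2, exchanges the whole group on the amine nitrogen and therefore does not bear on a shift of the chlorine within the phenyl ring. Within the data shown here, no measured pair speaks to this change. The expectation for compound 3 therefore rests on compound 2 alone, with a step estimated at a 1.8-fold higher number from compound 2 to compound 3 (0.26 log units; within the scatter), which may well fall within the scatter. Compound 3 is estimated to give 2 nM in this assay, with a range from 0.6 nM to 7 nM.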

Compound 3, inhibition constant: 0.68 nM
Estimate against measurement, compound 3: 2.9-fold (0.47 log units) above; measured number inside the range.
By their numbers in this assay, from the lowest: compounds 3 and 2 (each within the scatter of the next); then compound 1.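

Moving the chlorine on the ring attached to the sulfonyl sulfur, from 3-chlorophenyl to 2-chlorophenyl, gives in this assay a 1.6-fold lower number from compound 2 to compound 3 (0.21 log units; within the scatter), so this read-out does not separate the two placings of the chlorine. The advantage of the chlorophenylsulfonyl compounds over compound 1 is therefore not confined to the 3-chlorophenyl group: the second placing also stands clear of compound 1, with a 15-fold lower number from compound 1 to compound 3 (1.16 log units; beyond the scatter), and compounds 2 and 3 cannot be ranked against each other. Nothing available here accounts for this result.

The compounds shown leave open whether this tolerance extends beyond chlorine, for example to a methyl, a methoxy or a nitrile on the ring, or whether a plain phenyl on the sulfonyl sulfur would give a similar number. On these data alone, it also remains open how much of the step from compound 1 belongs to the sulfonyl in place of the carbonyl and how much to the ring and the ethenyl link, as these parts change together in both steps from compound 1.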